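A chloro added to the urea-linked aryl ring

This account rests on a few compounds, and the source may have more. Where it says the series, first, only, none or still open, it means among the compounds named here.

Compound 1 `COc1cc(-c2nn(-c3cccc(NC(=O)c4cccc(C(F)(F)F)c4)c3)cc2-c2ccncc2)ccc1Cl` carries an amide linker; in a functional assay on SW-620 cells (Homo sapiens) for inhibition, read by sulforhodamine B assay, with a stated time of 48 h (a lower number here means a stronger inhibitor of growth, a higher number a weaker inhibitor of growth), compound 1 reaches only the limit > 50000 nM. For the measured compounds named here, compound 2 `COc1cc(-c2nn(-c3cccc(NC(=O)Nc4cccc(C(F)(F)F)c4)c3)cc2-c2ccncc2)ccc1Cl` replaces that amide with a urea, and in this assay compound 2 gives 14300 nM, the only numerical value among the two measured compounds. That change gave an at least 3.4-fold lower number from compound 1 to compound 2 (0.54 log units; beyond the scatter). Compound 3 `COc1cc(-c2nn(-c3cccc(NC(=O)Nc4ccc(Cl)c(C(F)(F)F)c4)c3)cc2-c2ccncc2)ccc1Cl` differs from compound 2 by chloro in place of hydrogen on an aromatic carbon. Going by the values given here, no measured step covers this kind of change, so the expectation rests on compound 2 alone, with wide uncertainty. Compound 3 is estimated at 8000 nM, between 2500 nM and 25000 nM, an expected step of a 1.8-fold lower number from compound 2 to compound 3 (0.25 log units; within the scatter).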

Compound 3, concentration for total growth inhibition: 29900 nM
Estimate against measurement, compound 3: 3.7-fold (0.57 log units) below; measured number above the stated range.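

In this assay, chloro in place of hydrogen, ortho to the trifluoromethyl group, gives a 2.1-fold higher number from compound 2 to compound 3 (0.32 log units; beyond the scatter), so at this position on the urea-linked ring the added chloro modestly weakens growth inhibition. Against the amide, the step is an at least 1.6-fold lower number from compound 1 to compound 3 (0.22 log units; that floor lies within the scatter), which is only a floor and does not firmly place the urea compound 3 ahead. Compound 1 gives a limit, not a number: the limit of > 50000 nM in this assay, at which 1 of the 3 values shown sits.

From the compounds shown here alone, whether fluoro or an amine at this same place would keep or improve on compound 2 stays open. So does whether chloro has the same effect on the amide series.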